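Amide variants on a shared core: cell growth inhibition notes

This account rests on a few compounds, and the source may have more. Where it says the series, first, only, none or still open, it means among the compounds named here.

Measured compounds in a functional assay on MDA-MB-231 cells (Homo sapiens) for inhibition, read by MTT assay, with a stated time of 48 h; on this read-out higher numbers stand for weaker inhibition and lower numbers for stronger inhibition:
compound 1 `CC(C)n1c(/C=C2\SC(=O)N(CC(=O)N3CCOCC3)C2=O)nc2ccccc21` gives > 50000 nM, a limit of the assay.
compound 2 `CC(C)n1c(/C=C2\SC(=O)N(CC(=O)N3CCCCC3)C2=O)nc2ccccc21` gives > 50000 nM, a limit of the assay.
compound 3 `Cn1c(/C=C2\SC(=O)N(CC(=O)N3CCCCC3)C2=O)nc2ccccc21` gives > 50000 nM, a limit of the assay.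

Every value shown is a limit, not a number, because of the limit of > 50000 nM in this assay, at which 3 of the 3 values shown sit. Compound 2 therefore has no fixed place among the measured compounds, only a limit. The steps a step that the two limits leave unreadable from compound 1 to compound 2 and a step that the two limits leave unreadable from compound 2 to compound 3 stay unreadable for the same reason. Compound 4 `CC(C)n1c(/C=C2\SC(=O)N(CC(=O)Nc3cc(C(C)(C)C)on3)C2=O)nc2ccccc21` differs from compound 2 by (5-(tert-butyl)-1,2-oxazol-3-yl)amino in place of piperidin-1-yl on a carbonyl carbon. Neither measured step bears readably on this change, so no size or direction can be drawn from them. Compound 4 is expected to give 60000 nM in this assay, with a range of 15000 nM to 200000 nM, most likely again reported only as a limit. The estimated step that the limit leaves unreadable from compound 2 to compound 4 is expected to be no more than scatter.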

Compound 4, half-maximal inhibitory concentration: > 50000 nM
Compound 4: only a limit was reported (the forecaster's own chance of this, stated with the estimate: 75%); the middle value does not contradict the limit.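

No new step can be read from compound 1 or compound 2 to compound 4: the limit of > 50000 nM in this assay, at which 4 of the 4 values shown sit.

The compounds shown leave open whether any of these amides on the shared core reaches a measurable value in this assay, and how large the steps between them are.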